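This account rests on a few compounds, and the source may have more. Where it says the series, first, only, none or still open, it means among the compounds named here.

Measured so far:
- compound 1 `CCC(C)C(NC(=O)n1nnc2ccccc21)C(=O)NC1CCCCC1`, which in a functional assay on SW-620 cells (Homo sapiens) for inhibition (on this read-out lower numbers stand for stronger inhibition and higher numbers for weaker inhibition), gives > 100000 nM, a limit of the assay and not a number
- compound 2 `CC(C)C(NC(=O)n1nnc2ccccc21)C(=O)NC1CCCC1`, which in this assay gives > 200000 nM, likewise a limit of the assay

Compound 2 therefore stands on no measured number at all: its entry is a limit, (the limit of > 200000 nM in this assay, at which 1 of the 2 values shown sits). Among the compounds with values here, the only other value shown is also a limit, (the limit of > 100000 nM in this assay, at which 1 of the 2 values shown sits), so compound 2 can be placed neither above nor below compound 1 in this assay; both simply fall short of measurable inhibition.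

Compound 3 `CCC(C)C(NC(=O)n1nnc2ccccc21)C(=O)NC1CCCC1` differs from compound 2 by methyl in place of hydrogen on a saturated chain carbon, three bonds along the chain from an amide-type nitrogen and a carbonyl carbon, or, read one bond further out, isopropyl to sec-butyl. Within the data shown here, no measured pair shows this change on its own. Compound 1 already carries the sec-butyl and returns only a limit, which gives no reason to expect that compound 3 will climb into the measurable range. The expected step is a number no higher from compound 2 to compound 3 (the limit leaves the size open), meaning none beyond the scatter. Compound 3 is estimated at 200000 nM, within 50000 nM to 500000 nM, most likely again reported as a limit.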

Compound 3, half-maximal inhibitory concentration: > 100000 nM
Compound 3: only a limit was reported; the forecaster's own chance of this, stated with the estimate: 85%; the middle value does not contradict the limit.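

In this assay compound 3 gives > 100000 nM, a limit of the assay and not a number. Compound 1 and compound 2 are also limits, so neither the step from compound 2 to compound 3 nor the step from compound 1 to compound 3 can be read. The compounds shown leave open whether exchanging isopropyl for sec-butyl or cyclohexyl for cyclopentyl changes inhibition at all.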